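From Methoxy to Dimethylamino in a Small Series

The source may report more compounds than this note shows. Statements on the series, on what has been measured and on what is new or still open speak of the compounds shown alone.

In a functional assay on SW480 cells (Homo sapiens) for antiproliferative activity, read by sulforhodamine B assay, with a stated time of 48 h (a higher number here means a weaker inhibitor, a lower number a stronger inhibitor), compound 1 `COc1ccc(/C=C/C(=O)c2ccccc2-c2ccc(F)cc2)cc1` gives 61 nM. That lies within the scatter of compound 3 `COc1ccc(/C=C/C(=O)c2ccccc2-c2ccc(F)cc2)cc1B(O)O`, which gives 41 nM, and well apart from compound 2 `COc1ccc(/C=C/C(=O)c2ccccc2-c2ccc(F)cc2)cc1OC`, which gives 570 nM. Compound 4 `CN(C)c1ccc(/C=C/C(=O)c2ccccc2-c2ccc(F)cc2)cc1` has not yet been measured. It differs from compound 1 in one place: dimethylamino in place of methoxy on an aromatic carbon, with dimethylamino in place of methoxy on an aromatic carbon, para to a large group.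

Going by the values given here, no measured step replaces that methoxy, so the evidence is indirect. The modest step of a 9.3-fold higher number from compound 1 to compound 2 (0.97 log units; beyond the scatter) shows that a single change can lift the number beyond the scatter. The step of a 1.5-fold lower number from compound 1 to compound 3 (0.17 log units; within the scatter) stays within the scatter, and the large step of a 14-fold lower number from compound 2 to compound 3 (1.14 log units; beyond the scatter) runs the other way. With only these steps as a guide, a small rise is expected, held loosely. The expected step is a 2.1-fold higher number from compound 1 to compound 4 (0.33 log units; beyond the scatter). For compound 4 the estimated value is 130 nM, with an expected range of 35 nM to 500 nM.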

Compound 4, half-maximal inhibitory concentration: 41 nM
For compound 4 the middle estimate is 3.2-fold (0.50 log units) above the measured one; measured number inside the range.
By their numbers in this assay, from the lowest: compounds 3, 4 and 1 (each within the scatter of the next); then compound 2.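

In this assay, going by these compounds alone, the exchange of methoxy for dimethylamino, para to a large group, gives the first direct reading at this place: a 1.5-fold lower number from compound 1 to compound 4 (0.17 log units; within the scatter). Compounds 2 and 3 both keep that methoxy and carry their change elsewhere on the ring, so they could not show what happens when the methoxy itself is replaced. Here the replacement leaves the number within the scatter, and no measurement of any property of the two groups accompanies this result.

Still open, going by these compounds, is how far this holds for other groups at the same place, such as a primary amine, a hydroxyl or a longer chain like butoxy. Also open, on these data alone, is whether dimethylamino would give a similar reading alongside the extra group that compound 2 or compound 3 carries on the ring.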